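This account rests on a few compounds, and the source may have more. Where it says the series, first, only, none or still open, it means among the compounds named here.

Compound 2 `COc1ccc(OC)c(/C=C/C(=O)N/N=C/c2ccc(Cl)cc2)c1` gives the lowest number of the two values on hand: in a functional assay on MDA-MB-468 cells (Homo sapiens) for antiproliferative activity, read by sulforhodamine B assay, with a stated time of 48 h (on this read-out lower numbers stand for stronger inhibition of growth and higher numbers for weaker inhibition of growth), compound 2 gives 142 nM, whereas compound 1 `COc1ccc(OC)c(/C=C/c2nnc(Nc3ccc(Cl)cc3)o2)c1` gives 16400 nM in the same assay. Compound 3 `COc1ccc(OC)c(/C=C/C(=O)N/N=C/c2ccccc2)c1` is the next compound, and it differs from compound 2 by hydrogen in place of chloro on an aromatic carbon. Among the compounds with values here, no measured pair on hand shows the outcome of this particular change, so the expectation rests on compound 2 alone. Compound 3 is expected to give a somewhat higher number than compound 2, a step of a 2.5-fold higher number from compound 2 to compound 3 (0.39 log units; beyond the scatter) that may reach just beyond the scatter. The estimate for compound 3 is 350 nM, with a range from 120 nM to 1000 nM.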

Compound 3, concentration for 50% growth inhibition: 1960 nM
Beside the measured number, compound 3's estimate is 5.6-fold (0.75 log units) below it; the measured number lies above the stated range.
By their numbers in this assay, from the lowest: compound 2; then compound 3; then compound 1.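

In this assay, the change from 4-chlorophenyl to phenyl gives a 14-fold higher number from compound 2 to compound 3 (1.14 log units; beyond the scatter), a large step for the loss of a single heavy atom. This shows that growth inhibition in this series is sensitive to what sits on this aromatic carbon, para to a large group, and that the chloro contributes substantially to the number for compound 2. Nothing on hand explains why the step is so large. The compounds shown leave open whether fluoro, bromo, methoxy or an amine at this position would match chloro or fall closer to hydrogen.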